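Series Notes: Methyl to Hydrogen on the Aromatic Ring

The source may report more compounds than this note shows. Statements on the series, on what has been measured and on what is new or still open speak of the compounds shown alone.

Measured so far:
Compound 1 `COc1ccc(-c2nnc(SCCCN3CCN(c4nc5ccccc5o4)CC3)o2)cc1`: 52700 nM
Compound 2 `Cc1ccc(-c2nnc(SCCCN3CCN(c4nc5ccccc5o4)CC3)o2)cc1`: 100000 nM
Compound 3 `Fc1ccc(-c2nnc(SCCCN3CCN(c4nc5ccccc5o4)CC3)o2)cc1`: 136000 nM

In a functional assay on A-431 cells (Homo sapiens) for inhibition, read by MTT assay, with a stated time of 72 h (on this read-out higher numbers stand for weaker inhibition and lower numbers for stronger inhibition), compound 2 gives 100000 nM, the second highest of the three numbers. Its nearest neighbour is compound 3, which in this assay gives 136000 nM; the step of a 1.4-fold higher number from compound 2 to compound 3 (0.13 log units; within the scatter) is within the scatter. Compound 1, which in this assay gives 52700 nM, is the furthest, and the step of a 1.9-fold higher number from compound 1 to compound 2 (0.28 log units; within the scatter) is also within the scatter. Among the measured compounds shown here, the only step beyond the scatter is a 2.6-fold higher number from compound 1 to compound 3 (0.41 log units; beyond the scatter), and it is modest.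

The unmeasured compound 4 `c1ccc(-c2nnc(SCCCN3CCN(c4nc5ccccc5o4)CC3)o2)cc1` differs from compound 2 in one place: hydrogen in place of methyl on an aromatic carbon.

For the measured compounds named here, no measured step exchanges a substituent for hydrogen at this position, so none bears on the change directly. What the three measured compounds show is that swapping methoxy, methyl and fluoro at this aromatic carbon moves this assay by little: two steps within the scatter and one modest. On that basis compound 4 is expected to stay close to compound 2, with the step of no change at the digits printed from compound 2 to compound 4 (within the scatter) estimated to lie within the scatter, direction uncertain. Compound 4 is therefore estimated at 100000 nM in this assay, with a range from 45000 nM to 220000 nM.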

Compound 4, half-maximal inhibitory concentration: 57600 nM
For compound 4 the middle estimate is 1.7-fold (0.24 log units) above the measured one; the range from low to high includes it.
By their numbers in this assay, from the lowest: compounds 1, 4, 2 and 3 (each within the scatter of the next, the first and the last beyond it).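

In this assay the exchange for hydrogen can now be read directly, and a 1.7-fold lower number from compound 2 to compound 4 (0.24 log units; within the scatter) shows that losing the methyl of the 4-methylphenyl group leaves the number inside the usual scatter. Among the compounds shown here, likewise a 1.1-fold higher number from compound 1 to compound 4 (0.04 log units; within the scatter) places hydrogen within the scatter of methoxy, so at this aromatic carbon neither substituent can be told apart from having no substituent at all, while a 2.4-fold lower number from compound 3 to compound 4 (0.37 log units; beyond the scatter) is modest and beyond the scatter, which makes fluoro the one group here that separates from hydrogen, with the higher number. The series thus gives no sign that a substituent at this carbon is needed for the inhibition seen in this assay, and no available measurement accounts for the difference between fluoro and hydrogen.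

Going by these compounds, whether an amine, a carboxylic acid or a longer chain at this carbon would shift the number well beyond the small spread of these four compounds remains open. Also open, on these data alone, is whether the same order holds in cells other than those of this single read-out.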